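The compounds below may be only part of what the source reports. "The series", "measured", "known", "first", "only" and "open" are said of these compounds alone.

Of the compounds shown here, three of one series have been measured in an assay on isolated protein for inhibition of Alpha glucosidase (Homo sapiens), with stated times of 5 min and 15 min, tested at 50 uM; on this read-out higher numbers stand for more inhibition at the one concentration tested (going by the name of the read-out) and lower numbers for less inhibition. Compound 1, `O=C1/C(=C/c2ccccc2)CCC/C1=C\c1ccc(F)cc1`, gives 34% in this assay. Compound 2, `O=C1/C(=C/c2ccccc2)CCC/C1=C\c1ccc(Br)cc1`, gives 29.1%. Compound 3, `O=C1/C(=C/c2ccccc2)CCC/C1=C\c1cccc(F)c1`, gives 39.8%, the highest of the three numbers, though its separation from compound 1 is a number 5.8 percentage points higher from compound 1 to compound 3 (within the scatter) and the two cannot be ordered; against compound 2 the step is a number 10.7 percentage points higher from compound 2 to compound 3 (beyond the scatter).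

Compound 3 and compound 1 share their atoms and differ only in how they are joined, the difference being (3-fluorophenyl in place of 4-fluorophenyl on a double-bonded chain carbon bound to a double-bonded ring carbon). Compound 4, `O=C1/C(=C/c2ccccc2)CCC/C1=C\c1cccc(Br)c1`, is not yet measured in this assay. It differs from compound 3 by bromo in place of fluoro on an aromatic carbon.

The same kind of change is already in hand between compound 1 and compound 2, as bromo in place of fluoro on an aromatic carbon. There the change sits para to a large group, while in the new pair it sits meta to a large group, so the two changes are of the same kind rather than the same. The measured step was a number 4.9 percentage points lower from compound 1 to compound 2 (within the scatter), which lies within the scatter.

On that single precedent, the expected step in this assay is a number 4.3 percentage points lower from compound 3 to compound 4 (within the scatter), resting on the step of a number 4.9 percentage points lower from compound 1 to compound 2 (within the scatter) and the starting value of compound 3 at 39.8%. Compound 4 is therefore estimated at 35.5%, with the expected range running from 25% to 46%.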

Compound 4, a percentage reported as inhibition, at one concentration (the size of the read-out at that concentration, not a potency): 27.2%
Compound 4: the middle estimate sits 8.3 percentage points above what was measured; the range from low to high includes it.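

In this assay, bromo in place of fluoro on an aromatic carbon can now be read on two cores, and the two steps do not differ by more than two such steps normally scatter: the same change on two cores in this assay, a number 4.9 percentage points lower (within the scatter) from compound 1 to compound 2 and a number 12.6 percentage points lower (beyond the scatter) from compound 3 to compound 4, 7.7 percentage points apart, within the scatter of two such steps. Within the data shown here, only the new step, a number 12.6 percentage points lower from compound 3 to compound 4 (beyond the scatter), stands clear of the scatter on its own, so the two pairs show no measurable dependence on the core, but they do not fix a common size for the change and, with only two pairs, do not show that it transfers reliably across the series. The other two new steps, a number 1.9 percentage points lower from compound 2 to compound 4 (within the scatter) for 3-bromophenyl in place of 4-bromophenyl and a number 6.8 percentage points lower from compound 1 to compound 4 (within the scatter) for 3-bromophenyl in place of 4-fluorophenyl, separate neither pair of compounds, so the bromo compounds give no reading of a difference between the two ring positions.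

The substituted phenyl carries only fluoro or bromo in these compounds, which leaves open how chloro, methoxy, an amine or a carboxylic acid at the same place would read. As far as these compounds go, the unsubstituted phenyl on the other side of the shared core also stays open, and every number here gives the size of the effect at one concentration only.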